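The source may report more compounds than this note shows. Statements on the series, on what has been measured and on what is new or still open speak of the compounds shown alone.

Among the compounds with values here, in a functional assay on MDA-MB-435 cells (Homo sapiens) for inhibition, read by sulforhodamine B assay, with a stated time of 48 h (on this read-out higher numbers stand for weaker inhibition of growth and lower numbers for stronger inhibition of growth), compound 2 `COc1cccc(OC)c1/C=N/NC(=O)Cc1csc2nc(-c3ccc(Br)cc3)cn12` gives 3980 nM, the lower of the two numbers so far, and compound 1 `O=C(Cc1csc2nc(-c3ccc(Br)cc3)cn12)N/N=C/c1ccccc1` gives 12000 nM. Compound 3 `O=C(Cc1csc2nc(-c3ccc(Br)cc3)cn12)N/N=C/c1ccc(Cl)cc1Cl` has 2,4-dichlorophenyl in place of 2,6-dimethoxyphenyl on a carbon with a double bond to nitrogen. Within the data shown here, only one measured step bears on this change, the modest 3.0-fold lower number from compound 1 to compound 2 (0.48 log units; beyond the scatter), seen when 2,6-dimethoxyphenyl replaced phenyl. Among the measured compounds shown here, no measurement yet covers 2,4-dichlorophenyl, so only a small upward shift within the scatter is expected, a 1.5-fold higher number from compound 2 to compound 3 (0.18 log units; within the scatter). Compound 3 is estimated at 6000 nM, within a range of 2000 nM to 18000 nM.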

Compound 3, concentration for 50% growth inhibition: 31600 nM
Estimate against measurement, compound 3: 5.3-fold (0.72 log units) below, outside the stated range (above it).
By their numbers in this assay, from the lowest: compound 2; then compound 1; then compound 3.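

In this assay, changing the ring on the carbon with a double bond to nitrogen can weaken growth inhibition as well as strengthen it: 2,4-dichlorophenyl in place of 2,6-dimethoxyphenyl brings a 7.9-fold higher number from compound 2 to compound 3 (0.90 log units; beyond the scatter). Replacing plain phenyl with 2,4-dichlorophenyl also gives a 2.6-fold higher number from compound 1 to compound 3 (0.42 log units; beyond the scatter), so adding groups to this ring does not help in every case. Nothing available explains why these two substituted rings behave so differently. From the compounds shown here alone, whether the atoms added or their placement on the ring matters more remains open. So does the effect of a ring carrying an amine or a carboxylic acid.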